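A few compounds are considered here, and "the series" means these few. Any claim that something is new, unique, unknown or untested is made for them only; others in the source may bear on it.

Measured so far:
Compound 1, `Cc1c(Nc2nc(N)c3c(C#N)c(N4CCC[C@H]4C)n(C)c3n2)cnn1C`: in an assay on HEK293 cells for inhibition of Leucine-rich repeat serine/threonine-protein kinase 2 variant G2019S (Homo sapiens), with a stated time of 48 h (a lower number here means a stronger inhibitor, a higher number a weaker inhibitor), compound 1 gives 260 nM.
Compound 2, `Cc1c(Nc2nc(N)c3c(C#N)c(N4CCC[C@H]4C)n(C)c3n2)cnn1CC1(O)COC1`: compound 2 gives 120 nM.
Compound 3, `Cc1nn(C)cc1Nc1nc(N)c2c(C#N)c(N3CCC[C@H]3C)n(C)c2n1`: compound 3 gives 120 nM.

Compound 4, `Cc1nn(CC2(O)COC2)cc1Nc1nc(N)c2c(C#N)c(N3CCC[C@H]3C)n(C)c2n1`, has not been measured. It differs from compound 3 by 3-hydroxyoxetan-3-yl in place of hydrogen on a saturated chain carbon bound to an aromatic nitrogen. The same change has already been made once, from compound 1 to compound 2, as 3-hydroxyoxetan-3-yl in place of hydrogen on a saturated chain carbon bound to an aromatic nitrogen, where it gave a 2.2-fold lower number from compound 1 to compound 2 (0.34 log units; beyond the scatter). The two places are described in the same words, so the change is made on the same kind of site. The cores themselves differ by 1,3-dimethyl-1H-pyrazol-4-yl in place of 1,5-dimethyl-1H-pyrazol-4-yl on a nitrogen on an aromatic ring, a change that gave a 2.2-fold lower number from compound 1 to compound 3 (0.34 log units; beyond the scatter). Among the compounds with values here, a step of about the same modest size is expected from compound 3 to compound 4, a 2.2-fold lower number from compound 3 to compound 4 (0.34 log units; beyond the scatter), because the one earlier instance gave a 2.2-fold lower number from compound 1 to compound 2 (0.34 log units; beyond the scatter); with a single precedent, the uncertainty stays wide. In this assay compound 4 is therefore expected to give 55 nM, plausibly between 25 nM and 130 nM.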

Compound 4, half-maximal inhibitory concentration: 250 nM
Estimate against measurement, compound 4: 4.5-fold (0.66 log units) below; measured number outside the range, above it.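

In this assay, adding the 3-hydroxyoxetan-3-yl group gives a 2.1-fold higher number from compound 3 to compound 4 (0.32 log units; beyond the scatter), whereas the same change lowered the number on the core of compound 1. Set side by side, the two steps run in opposite directions and differ by more than repeat measurements would explain: the same change on two cores in this assay, a 2.2-fold lower number (0.34 log units; beyond the scatter) from compound 1 to compound 2 and a 2.1-fold higher number (0.32 log units; beyond the scatter) from compound 3 to compound 4, 4.5-fold (0.65 log units) apart, beyond the scatter of two such steps This shows that the effect of this change cannot simply be carried from one core to the other in this series, but two examples do not show why the cores respond differently or what a third core would do.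

The compounds shown leave open how another group at the same saturated chain carbon, such as a carboxylic acid or a longer chain, would behave on each core.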